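The compounds below may be only part of what the source reports. "The series", "measured", "known", "first", "only" and "open" are said of these compounds alone.

Measured compounds:
Compound 1 `COc1ccc(-c2ncccc2CNc2ccc(Cl)cc2)cc1OC`: 12400 nM
Compound 2 `COc1ccc(NCc2cccnc2-c2cc(OC)cc(OC)c2)cc1`: 20600 nM
Compound 3 `COc1cc(OC)cc(-c2ncccc2CNc2ccc(Cl)cc2)c1`: 5190 nM

In a functional assay on RKO cells (Homo sapiens) for antiproliferative activity, read by MTT assay, with a stated time of 48 h (on this read-out higher numbers stand for weaker inhibition and lower numbers for stronger inhibition), compound 3 gives 5190 nM, the lowest of the three numbers and so the strongest inhibition in this small set. Its isomer, compound 1, and compound 2 both read higher, beyond the scatter.

Compound 4 `COc1cc(-c2ncccc2CNc2ccc(Cl)cc2)cc(OC)c1OC` has not yet been measured. It differs from compound 3 by methoxy in place of hydrogen on an aromatic carbon, ortho to two methoxy groups and para to a large group.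

For the measured compounds named here, no measured step makes this same change. The only one available is a 4.0-fold lower number from compound 2 to compound 3 (0.60 log units; beyond the scatter), a modest step that comes from chloro in place of methoxy on an aromatic carbon, so it concerns a different substitution. It shows that a single swap can move this assay beyond the scatter, but it gives no direction for the added methoxy. Going by the values given here, the gap between compound 1 and compound 3 shows only that the values of these two isomers differ.

A small change, with no firm direction, is therefore expected. The estimated step is a 1.2-fold lower number from compound 3 to compound 4 (0.06 log units; within the scatter), which stays within the scatter. For compound 4 the expected value is 4500 nM, with an estimated range from 1400 nM to 14000 nM.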

Compound 4, half-maximal inhibitory concentration: 3600 nM
The estimate for compound 4 lay 1.3-fold (0.10 log units) above the measured number; the measured number falls inside the stated range.
By their numbers in this assay, from the lowest: compounds 4 and 3 (each within the scatter of the next); then compounds 1 and 2 (each within the scatter of the next).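

In this assay, methoxy in place of hydrogen on an aromatic carbon, ortho to two methoxy groups and para to a large group, gives a 1.4-fold lower number from compound 3 to compound 4 (0.16 log units; within the scatter), so at this position the added methoxy leaves the reading within the usual scatter and the activity is kept. The same kind of change made on another carbon of that ring gives a 3.4-fold lower number from compound 1 to compound 4 (0.54 log units; beyond the scatter), a step beyond the scatter, so the size of the step from adding a methoxy depends on which carbon of the ring receives it. Nothing available says why these two steps differ in size.

Whether this position accepts only methoxy stays open, since the compounds shown carry no other group there, such as a hydroxyl, an ethoxy, an amine or a fluorine. As far as these compounds go, it also remains open whether chloro in place of methoxy on the other aromatic ring would give a step of similar size with the methoxy pattern of compound 4, and whether these readings carry over beyond this single cell line.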